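This account rests on a few compounds, and the source may have more. Where it says the series, first, only, none or still open, it means among the compounds named here.

Working notes on a short series of three measured analogues and one untested one in an ADME assay on HEK293 cells (Homo sapiens) for cytotoxicity, read by MTT assay, with a stated time of 44 h; on this read-out higher numbers stand for weaker inhibition and lower numbers for stronger inhibition. Compound 1 `Clc1ccc(C2ON=C(c3ccccc3Cl)O2)cc1` is recorded only as a limit of the assay: in this assay compound 1 gives > 100000 nM. Compound 2 `Clc1ccc(C2=NOC(c3ccc(Cl)c(Cl)c3)O2)cc1` is likewise recorded as a limit, compound 2 giving > 100000 nM in this assay. Compound 3 `Clc1ccc(C2=NOC(c3ccc(Cl)cc3)O2)cc1` also stands at a limit, with compound 3 giving > 100000 nM in this assay. Among the measured compounds shown here, the only single-point step among the measured compounds, a step that the two limits leave unreadable from compound 2 to compound 3, has no readable size, as both of its values are limits; every value in the set sits at the limit of > 100000 nM in this assay, at which 3 of the 3 values shown sit. Compound 3 therefore stands exactly where the other two stand, at the limit and nowhere more precise.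

Compound 4 `Cc1ccc(C2ON=C(c3ccc(Cl)cc3)O2)cc1` differs from compound 3 by methyl in place of chloro on an aromatic carbon. For the measured compounds named here, no measured step with a readable size bears on this change; the series so far offers only limits. Compound 4 is expected to stay at the same limit, with an estimate of 150000 nM and a range from 60000 nM to 500000 nM. The step that this estimate means is expected to be a step that the limit leaves unreadable from compound 3 to compound 4, nothing beyond the scatter.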

Compound 4, half-maximal inhibitory concentration: > 100000 nM
Compound 4: only a limit was reported; the forecaster's own chance of this, stated with the estimate: 85%; the middle value is on the limit's open side.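

No step from compound 3 to compound 4 can be read in this assay, since both values are limits: the limit of > 100000 nM in this assay, at which 4 of the 4 values shown sit.

The compounds shown leave open how methyl and chloro compare at this position, and whether any analogue of the shared core gives a readable value in this assay.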